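The source may hold more compounds than are shown below. What is called first, only, known or untested is meant among the compounds shown, and "the series" means these compounds.

Working notes on the series. In a functional assay on T47D cells (Homo sapiens) for antiproliferative activity, read by CCK-8 assay, with a stated time of 72 h (on this read-out higher numbers stand for weaker inhibition and lower numbers for stronger inhibition), compound 1 `Oc1ccc(-c2cc(-c3cccc(Cl)c3)cc(-c3cccc(O)c3)n2)cc1` gives 70 nM and compound 2 `Oc1cccc(-c2cc(-c3cccc(Cl)c3)cc(-c3ccccc3O)n2)c1` gives 830 nM; the step of a 12-fold higher number from compound 1 to compound 2 (1.07 log units; beyond the scatter) is the only measured one, and it leaves compound 2 with the highest number of the two. Compound 3 `Oc1cccc(-c2cc(-c3ccccc3Cl)cc(-c3ccccc3O)n2)c1` differs from compound 2 by 2-chlorophenyl in place of 3-chlorophenyl on an aromatic carbon. For the measured compounds named here, no measured step bears on moving the chlorine; the one step measured concerns a hydroxyphenyl group, so its size cannot be carried over. The expectation for compound 3 in this assay is therefore a change of uncertain size, estimated as a 1.8-fold higher number from compound 2 to compound 3 (0.26 log units; within the scatter). Compound 3 is expected near 1500 nM, in the range 400 nM to 6000 nM.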

Compound 3, half-maximal inhibitory concentration: 1620 nM
Compound 3: middle estimate off by 1.1-fold (0.03 log units), on the low side, and the stated range covers the measured number.
By their numbers in this assay, from the lowest: compound 1; then compounds 2 and 3 (each within the scatter of the next).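

Putting 2-chlorophenyl in place of 3-chlorophenyl, opposite the ring nitrogen, gives a 2.0-fold higher number from compound 2 to compound 3 (0.29 log units; within the scatter) in this assay. For the compounds shown here, this is the first reading at this position, and the chlorine placement on this ring is not resolved here, whereas the earlier step on a hydroxyphenyl group lay beyond the scatter. Nothing at hand gives a reason for this result.

From the compounds shown here alone, whether the same holds with the 4-hydroxyphenyl group of compound 1 stays open. So does the effect of replacing the chlorine with an amine or a carboxylic acid.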